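Permeability notes: aryl replacement on the shared core

The compounds below may be only part of what the source reports. "The series", "measured", "known", "first", "only" and "open" are said of these compounds alone.

compound 1 `COc1cccc(CNCCCNc2ccnc3cc(Oc4ccc(F)cc4)ccc23)c1O` — 317 10^-6 cm/s
compound 2 `Fc1ccc(Oc2ccc3c(NCCCNCc4ccco4)ccnc3c2)cc1` — 317 10^-6 cm/s
compound 3 `COc1ccc(-c2ccc3c(NCCCNCc4ccco4)ccnc3c2)cc1` — 237 10^-6 cm/s

In an ADME assay for permeability, using PAMPA, with a stated time of 30 min, at pH 7.4 (a lower number here means that the compound crosses the layer more slowly, a higher number that the compound crosses the layer faster), compound 1 gives 317 10^-6 cm/s. Compound 2 gives 317 10^-6 cm/s, level with compound 1, and the step of no change at the digits printed from compound 1 to compound 2 (within the scatter) is within the scatter. Compound 3 gives 237 10^-6 cm/s; the step of a 1.3-fold lower number from compound 2 to compound 3 (0.13 log units; within the scatter) also stays within the scatter, so all three measured numbers sit close together.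

Compound 4 `COc1cccc(CNCCCNc2ccnc3cc(Cc4ccc(C#N)cc4)ccc23)c1O` is not yet measured. It differs from compound 1 by 4-cyanobenzyl in place of 4-fluorophenoxy on an aromatic carbon. Within the data shown here, of the measured steps, the one from compound 2 to compound 3 touches the same aromatic carbon of the core and changed the number by a 1.3-fold lower number from compound 2 to compound 3 (0.13 log units; within the scatter), within the scatter. The step from compound 1 to compound 2 alters a different part of the molecule and is likewise within the scatter. Among the measured compounds shown here, no measured step introduces a benzyl or a nitrile, so the present change has no direct precedent here.

On this basis the expected step for compound 4 in this assay is small, a 1.1-fold lower number from compound 1 to compound 4 (0.05 log units; within the scatter), with no direction beyond the scatter. Compound 4 is estimated at 280 10^-6 cm/s, within the range 150 10^-6 cm/s to 500 10^-6 cm/s.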

Compound 4, apparent permeability: 23 10^-6 cm/s
For compound 4 the middle estimate is 12-fold (1.09 log units) above the measured one; the measured number lies below the stated range.
By their numbers in this assay, from the lowest: compound 4; then compounds 3, 1 and 2 (each within the scatter of the next).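

In this assay, among these compounds, the substituent on this aromatic carbon of the shared core can matter: 4-cyanobenzyl in place of 4-fluorophenoxy gives a 14-fold lower number from compound 1 to compound 4 (1.14 log units; beyond the scatter), the only step so far beyond the scatter. The other change at this carbon, 4-methoxyphenyl in place of 4-fluorophenoxy, gives a 1.3-fold lower number from compound 2 to compound 3 (0.13 log units; within the scatter), so a replacement here can leave the number within the scatter or shift it by a large step, although the two steps were read on different side chains. No measurement available here accounts for the large step.

From the compounds shown here alone, whether a plain benzyl, a 4-fluorobenzyl or a 4-cyanophenoxy group on the same carbon would read like compound 1 or like compound 4 remains open, so the carbon link and the nitrile cannot yet be told apart. Also open, going by these compounds, is whether 4-cyanobenzyl gives a similar step on the furan-2-yl side chain of compound 2.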